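Removing one methoxy: what happens to compound 3

This account rests on a few compounds, and the source may have more. Where it says the series, first, only, none or still open, it means among the compounds named here.

Compound 1 `COc1cc(-c2cc(/C=C/C(=O)c3ccc(Cl)c(Cl)c3)[nH]n2)cc(OC)c1OC` and compound 2 `COc1ccc(C(=O)/C=C/c2cc(-c3cc(OC)c(OC)c(OC)c3)n[nH]2)cc1OC` share a core and differ only in the ring on the carbonyl carbon. In a functional assay on HCT-116 cells (Homo sapiens) for cytotoxicity, read by sulforhodamine B assay, with a stated time of 48 h, tested at 1 uM (on this read-out higher numbers stand for a weaker effect at the one concentration tested and lower numbers for a stronger effect), compound 1 gives 80% and compound 2 gives 47%, the lower of the two numbers, and the step of a number 33 percentage points lower from compound 1 to compound 2 (beyond the scatter) lies beyond the scatter. Compound 3 `COc1ccc(C(=O)/C=C/c2cc(-c3cc(OC)c(OC)c(OC)c3)n[nH]2)cc1` differs from compound 2 by hydrogen in place of methoxy on an aromatic carbon. Among the measured compounds shown here, no measured step removes a single methoxy, so the only step known involves a different change. A small shift, expected as a number 8 percentage points higher from compound 2 to compound 3 (within the scatter), is estimated for compound 3, giving 55% within 35% to 80%.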

Compound 3, a percentage reported as activity, at one concentration (the size of the read-out at that concentration, not a potency): 72%
Estimate against measurement, compound 3: 17 percentage points below; the measured number falls inside the stated range.
By their numbers in this assay, from the lowest: compound 2; then compounds 3 and 1 (each within the scatter of the next).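

In this assay this position matters: losing the one methoxy that turns 3,4-dimethoxyphenyl into 4-methoxyphenyl gives a number 25 percentage points higher from compound 2 to compound 3 (beyond the scatter) and so costs much of the effect at the one concentration tested. The remaining methoxy does not set compound 3 apart from the 3,4-dichlorophenyl compound, as a number 8 percentage points lower from compound 1 to compound 3 (within the scatter) shows, so of these three rings only 3,4-dimethoxyphenyl stands out. Nothing measured here explains why the methoxy has this effect. Still open, going by these compounds, is whether a hydroxyl or an amine at this position would keep the number of compound 2, and whether the remaining methoxy matters as much.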